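The source may hold more compounds than are shown below. What is called first, only, known or untested is meant among the compounds shown, and "the series" means these compounds.

Working notes on the series sharing one core, read in a functional assay on ACHN cells (Homo sapiens) for inhibition, read by sulforhodamine B assay; on this read-out higher numbers stand for weaker inhibition of growth and lower numbers for stronger inhibition of growth. Compound 3 `Cc1ccc(CN2CCC=C(CCC(=O)NO)C2=O)cc1` gives 5000 nM. Compound 1 `COc1cccc(CN2CCC=C(CCC(=O)NO)C2=O)c1` gives 7600 nM. Within the data shown here, these are the only two numbers available, and they lie within the scatter of each other, so compound 3 stands level with compound 1 and no order can be drawn between them. Compound 2 `O=C(CCC1=CCCN(Cc2ccc(F)cc2)C1=O)NO` adds nothing to the comparison, as its entry reads "not determined" (no result reported).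

The next compound to be read is compound 4 `Cc1cccc(CN2CCC=C(CCC(=O)NO)C2=O)c1`, which has the same atoms as compound 3, joined differently. It carries 3-methylphenyl in place of 4-methylphenyl on a saturated chain carbon bound to an amide-type nitrogen in a ring.

Among the measured compounds shown here, no measured pair differs in one place only, so no direct precedent exists for this change. The expectation rests on the two available numbers, compound 1 at 7600 nM and compound 3 at 5000 nM, which show no separation beyond the scatter. No step beyond the scatter is expected in this assay, in either direction. The estimated step is a 1.1-fold higher number from compound 3 to compound 4 (0.04 log units; within the scatter). For compound 4 the expected value is 5500 nM, with an estimated range of 2500 nM to 12000 nM.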

Compound 4, concentration for 50% growth inhibition: 4380 nM
Estimate against measurement, compound 4: 1.3-fold (0.10 log units) above, and the stated range covers the measured number.
By their numbers in this assay, from the lowest: compounds 4, 3 and 1 (each within the scatter of the next).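

In this assay, among these compounds, 3-methylphenyl in place of 4-methylphenyl on a saturated chain carbon bound to an amide-type nitrogen in a ring gives a 1.1-fold lower number from compound 3 to compound 4 (0.06 log units; within the scatter), the first comparison that differs in one place only, and it shows no separation between these two placements of the methyl group. Methyl in place of methoxy on an aromatic carbon gives a 1.7-fold lower number from compound 1 to compound 4 (0.24 log units; within the scatter), so this exchange of substituent on the aromatic ring also stays within the scatter, and neither change separates the compounds in this read-out. No measurement is at hand that bears on the reason for either result.

The compounds shown leave open whether a group of another kind on the aromatic ring, such as an amine or a carboxylic acid, would give a step beyond the scatter from compound 4. Also open, as far as these compounds go, is whether a longer chain in place of the saturated chain carbon on the amide-type nitrogen would change the number at all.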